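Working notes: a chloro step on the cytotoxicity series

This account rests on a few compounds, and the source may have more. Where it says the series, first, only, none or still open, it means among the compounds named here.

Compound 1 `O=C(Nc1ccc(Sc2nc3ccccc3s2)cc1)c1cc(Br)cc(Br)c1O` gives 66000 nM in an ADME assay on HEK293 cells (Homo sapiens) for cytotoxicity, read by reporter gene assay and resazurin assay, with a stated time of 48 h; a higher number here means that more compound is tolerated, a lower number that less compound is tolerated. Compound 2 `COc1c(Br)cc(Br)cc1C(=O)Nc1ccc(Sc2nc3ccccc3s2)cc1` reaches only the limit > 100000 nM in this assay. Compound 3 `COc1ccccc1C(=O)Nc1ccc(Sc2nc3ccccc3s2)cc1` likewise reaches only the limit > 100000 nM. The two measured steps, an at least 1.5-fold higher number from compound 1 to compound 2 (0.18 log units; that floor lies within the scatter) and an at least 1.5-fold higher number from compound 1 to compound 3 (0.18 log units; that floor lies within the scatter), both end at the limit of > 100000 nM in this assay, at which 2 of the 3 values shown sit. Going by the values given here, compound 2 therefore stands at the limit together with compound 3, and compound 1 is the only compound of the three with a number. Compound 4 `COc1c(Br)cc(Br)cc1C(=O)Nc1ccc(Sc2nc3ccccc3s2)c(Cl)c1` differs from compound 2 by chloro in place of hydrogen on an aromatic carbon. Among the compounds with values here, no measured step covers this change, and both measured steps run into the limit, so no movement beyond the scatter is expected in this assay. For compound 4 the estimate is 100000 nM, range 50000 nM to 200000 nM, which means an expected step of a number no higher from compound 2 to compound 4 (the limit leaves the size open).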

Compound 4, half-maximal cytotoxic concentration: > 100000 nM
Compound 4 ended at the assay's limit; the forecaster's own chance of this, stated with the estimate: 75%; the middle value sits exactly at the limit.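

Compound 2 and compound 4 both stand only at a limit, so no step can be read for this pair in this assay: the limit of > 100000 nM in this assay, at which 3 of the 4 values shown sit.

On these data alone, whether chloro in place of hydrogen on an aromatic carbon changes the number at all stays open.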